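Dibromo analogue awaiting measurement against three inactive hydrazones

This account rests on a few compounds, and the source may have more. Where it says the series, first, only, none or still open, it means among the compounds named here.

Compound 1 `COc1cc(/C=N/Nc2nc(-c3cc(C(F)(F)F)cc(C(F)(F)F)c3)cs2)cc(Br)c1OC` gives in a functional assay on Caco-2 cells (Homo sapiens) for inhibition, read by MTT assay, with a stated time of 48 h (on this read-out lower numbers stand for stronger inhibition and higher numbers for weaker inhibition), only a limit of the assay, > 100000 nM.
Compound 2 `COc1ccccc1-c1csc(N/N=C/c2cc(OC)c(OC)c(Br)c2Br)n1` gives in this assay only a limit of the assay, > 100000 nM.
Compound 3 `COc1ccccc1-c1csc(N/N=C/c2cc(Br)c(OC)c(OC)c2)n1` gives in this assay only a limit of the assay, > 100000 nM.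

None of the three measured values is a number; each is a limit, and all three sit at the same place, namely (the limit of > 100000 nM in this assay, at which 3 of the 3 values shown sit). Compound 3 and compound 2 differ in one place, (bromo in place of hydrogen on an aromatic carbon). The step that the two limits leave unreadable from compound 3 to compound 2 cannot be read, since both ends are limits. The cores of compound 1 and compound 3 differ in more than one place, and that difference is not broken down here.

Compound 4 `COc1cc(/C=N/Nc2nc(-c3cc(C(F)(F)F)cc(C(F)(F)F)c3)cs2)c(Br)c(Br)c1OC` has not yet been measured in this assay. Within the data shown here, it differs from compound 1 by bromo in place of hydrogen on an aromatic carbon, which is the same change, in the same surroundings, as the one made from compound 3 to compound 2. Among the measured compounds shown here, nothing among the measured compounds shows this change producing a readable value, and compound 1 itself is known only as a limit.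

On that basis compound 4 is expected to give 150000 nM, a step that the limit leaves unreadable from compound 1 to compound 4, and most likely to be reported again as a limit rather than a number. The estimated range for compound 4 runs from 60000 nM to 400000 nM.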

Compound 4, half-maximal inhibitory concentration: > 100000 nM
Compound 4 gave a limit, no number; the forecaster's own chance of this, stated with the estimate: 85%; the middle value does not contradict the limit.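

Compound 1 and compound 4 are both known only as limits of the assay, so no step can be read between them, just as none can be read between compound 3 and compound 2. All four compounds stand at one place: the limit of > 100000 nM in this assay, at which 4 of the 4 values shown sit.

The compounds shown leave open how strongly any of them inhibits in this assay, and whether bromo in place of hydrogen on an aromatic carbon changes that inhibition at all.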